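Methoxy in place of phenol on the compound 2 core

A few compounds are considered here, and "the series" means these few. Any claim that something is new, unique, unknown or untested is made for them only; others in the source may bear on it.

Compound 2 `O=C(Nc1cccc(-n2cc(-c3ccncc3)c(-c3ccc(Cl)c(O)c3)n2)c1)Nc1cc(C(F)(F)F)cc(C(F)(F)F)c1` is the reference for this step. In a functional assay on SNB-75 cells (Homo sapiens) for inhibition, read by sulforhodamine B assay, with a stated time of 48 h (a higher number here means a weaker inhibitor of growth, a lower number a stronger inhibitor of growth), compound 2 gives 2180 nM, the lower of the two numbers obtained, with compound 1 `COc1cc(-c2nn(-c3cccc(NC(=O)c4ccc(Cl)c(C(F)(F)F)c4)c3)cc2-c2ccncc2)ccc1Cl` standing higher at 29200 nM. Compound 3 `O=C(Nc1cccc(-n2cc(-c3ccncc3)c(-c3ccc(Cl)c(O)c3)n2)c1)Nc1cccc(C(F)(F)F)c1` returns only a limit, > 32500 nM, in this assay. Among the measured compounds shown here, the one step measured in one place, an at least 14-fold higher number from compound 2 to compound 3 (1.17 log units; beyond the scatter), sits on the urea side of the molecule and rests on a limit, as noted in the limit of > 32500 nM in this assay, at which 1 of the 3 values shown sits.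

Compound 4 `COc1cc(-c2nn(-c3cccc(NC(=O)Nc4cc(C(F)(F)F)cc(C(F)(F)F)c4)c3)cc2-c2ccncc2)ccc1Cl` differs from compound 2 elsewhere: methyl in place of hydrogen on an oxygen on an aromatic ring. For the measured compounds named here, no measured step touches this oxygen, so nothing measured bears directly on it. Going by the values given here, compound 1 also carries the methoxy group but differs from compound 2 in the linker as well, and its two values with compound 2 show only that the amide analogue stands higher. The expected step is therefore small, a 1.8-fold higher number from compound 2 to compound 4 (0.26 log units; within the scatter), with a lean toward a higher number. Compound 4 is estimated at 4000 nM, within 1500 nM to 12000 nM.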

Compound 4, concentration for total growth inhibition: 2070 nM
The estimate for compound 4 lay 1.9-fold (0.29 log units) above the measured number, and the stated range covers the measured number.
By their numbers in this assay, from the lowest: compounds 4 and 2 (each within the scatter of the next); then compound 1. At a limit, above all of these: compound 3.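

In this assay, the first step read at this oxygen is a 1.1-fold lower number from compound 2 to compound 4 (0.02 log units; within the scatter), so on the core of compound 2 the change from hydroxy to methoxy leaves the growth-inhibition number within the scatter, and the hydrogen on this oxygen is not needed to keep that number. The only other step read in one place, an at least 14-fold higher number from compound 2 to compound 3 (1.17 log units; beyond the scatter), rests on a limit and sits on the urea side, so in the compounds shown the sensitivity lies on that side and not at this oxygen. Nothing measured here accounts for the lack of a shift at this oxygen.

On these data alone, whether a longer chain on this oxygen, such as ethoxy or a benzyl ether, is accepted as well stays open. So does the effect of replacing the hydroxy with an amine or a carboxylic acid.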